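Adding trifluoromethyl to compound 2

The source may report more compounds than this note shows. Statements on the series, on what has been measured and on what is new or still open speak of the compounds shown alone.

Two compounds built on a shared core have been followed in an ADME assay on the whole organism (Rattus norvegicus, strain Sprague-Dawley) for pharmacokinetics, read by LC-MS, with a stated time of 30 min, at a dose of 1 mg/kg by the intravenous route; on this read-out lower numbers stand for slow clearance and higher numbers for fast clearance. Going by the values given here, compound 1 `N#Cc1ccc(S(=O)(=O)N2C[C@H](S(=O)(=O)c3ccc(Cl)cc3)[C@](O)(CO)C2)c(Cl)c1` gives 49 mL/min/kg and compound 2 `N#Cc1ccc(S(=O)(=O)N2C[C@H](S(=O)(=O)c3ccc(Cl)cc3)[C@](O)(CO)C2)cn1` gives 22 mL/min/kg, the lower of the two numbers so far. Among the compounds with values here, the one measured step between them is a 2.2-fold lower number from compound 1 to compound 2 (0.35 log units; beyond the scatter). It is modest but beyond the scatter, and it came with an exchange of the aromatic group on a sulfonyl sulfur.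

Compound 3 `N#Cc1ccc(S(=O)(=O)N2C[C@H](S(=O)(=O)c3ccc(Cl)cc3)[C@](O)(CO)C2)c(C(F)(F)F)n1` changes that same aromatic group again: trifluoromethyl in place of hydrogen on an aromatic carbon. Trifluoromethyl stands in place of hydrogen on an aromatic carbon, next to the ring nitrogen and meta to a cyano group. Within the data shown here, no measured step adds this group, so the direction remains an open question. Among the measured compounds shown here, the only guide to size is the step of a 2.2-fold lower number from compound 1 to compound 2 (0.35 log units; beyond the scatter), and a step of no greater size is expected here, with a slight lean towards a higher number. The expected change is a 1.4-fold higher number from compound 2 to compound 3 (0.13 log units; within the scatter). Compound 3 is estimated at 30 mL/min/kg, with an expected range from 13 mL/min/kg to 65 mL/min/kg.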

Compound 3, clearance: 310 mL/min/kg
Estimate against measurement, compound 3: 10-fold (1.01 log units) below; the measured number lies above the stated range.
By their numbers in this assay, from the lowest: compound 2; then compound 1; then compound 3.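

In this assay, the aromatic group on the sulfonyl sulfur proves far more sensitive to a change at this one carbon than the earlier pair could show: the new change gives a 14-fold higher number from compound 2 to compound 3 (1.15 log units; beyond the scatter), a large step, whereas exchanging the whole aromatic group gave only a 2.2-fold lower number from compound 1 to compound 2 (0.35 log units; beyond the scatter). A single replacement, trifluoromethyl in place of hydrogen on an aromatic carbon next to the ring nitrogen and ortho to a large group, is enough to take the series from the lowest clearance seen so far to the highest, so this position cannot be treated as a tolerant place for substitution on this read-out. The data shown offer no measurement that would explain why clearance rises so sharply here.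

Still open, as far as these compounds go, is whether this step belongs to trifluoromethyl itself or to any group on this carbon, since only hydrogen and trifluoromethyl are compared there. A methyl group, a methoxy group or an amine at the same carbon would help to separate these two readings, and would show whether clearance rises gradually or only with trifluoromethyl.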